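A few compounds are considered here, and "the series" means these few. Any claim that something is new, unique, unknown or untested is made for them only; others in the source may bear on it.

Measured so far:
compound 1 `COc1cc(-c2ccnc3cc(-c4ccc(-c5cnn(C)c5)cc4)nn23)cc(OC)c1OC`: 2110 nM
compound 2 `COc1cc(-c2ccnc3cc(-c4cccc5c4ccn5CO)nn23)cc(OC)c1OC`: 861 nM

In a functional assay on HCT-116 cells (Homo sapiens) for inhibition, read by CCK-8 assay, with a stated time of 48 h (on this read-out higher numbers stand for weaker inhibition and lower numbers for stronger inhibition), compound 1 gives 2110 nM, the higher of the two numbers shown. Compound 2 gives 861 nM, a gap beyond the usual scatter, so compound 1 is the weaker inhibitor of the pair.

Compound 3 `C=Cc1ccc(-c2cc3nccc(-c4cc(OC)c(OC)c(OC)c4)n3n2)cc1` is not yet measured. It differs from compound 1 in one place: vinyl in place of 1-methyl-1H-pyrazol-4-yl on an aromatic carbon. For the measured compounds named here, no measured pair covers this kind of change, so the size of the step is uncertain.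

For compound 3 a modest step toward weaker inhibition is expected in this assay, possibly within scatter, as a 1.5-fold higher number from compound 1 to compound 3 (0.18 log units; within the scatter). Compound 3 is estimated at 3200 nM, with a range from 1000 nM to 10000 nM.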

Compound 3, half-maximal inhibitory concentration: 1060 nM
For compound 3 the middle estimate is 3.0-fold (0.48 log units) above the measured one; the range from low to high includes it.
By their numbers in this assay, from the lowest: compounds 2, 3 and 1 (each within the scatter of the next, the first and the last beyond it).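

In this assay the data show a 2.0-fold lower number from compound 1 to compound 3 (0.30 log units; within the scatter) when vinyl replaces 1-methyl-1H-pyrazol-4-yl on the six-membered aromatic ring of carbon only, para to a large group. This position therefore accepts the loss of the five-membered aromatic ring and its 2 hydrogen-bond acceptors without a step beyond the scatter. Nothing available explains this result.

Going by these compounds, whether an amine, a carboxylic acid or a longer chain at this position would give a step beyond the scatter remains open. Also open, on these data alone, is whether this step would hold with other groups on the shared core.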